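The source may report more compounds than this note shows. Statements on the series, on what has been measured and on what is new or still open speak of the compounds shown alone.

Measured so far in an assay on isolated protein for inhibition of Amine oxidase [flavin-containing] A (Homo sapiens), read by spectrophotometry; a lower number here means a stronger inhibitor, a higher number a weaker inhibitor:

- compound 1 `COc1ccccc1/C=N/Nc1nc2ccccc2nc1Cc1ccccc1`: 83 nM
- compound 2 `C(=N/Nc1nc2ccccc2nc1Cc1ccccc1)\c1ccccc1`: 81 nM

Compound 2 gives the lowest of the two numbers in this assay, but the nearest compound, compound 1, sits within the scatter: a 1.0-fold lower number from compound 1 to compound 2 (0.01 log units; within the scatter), hydrogen in place of methoxy on an aromatic carbon. The two values therefore cannot be told apart.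

Compound 3 `Clc1ccc(/C=N/Nc2nc3ccccc3nc2Cc2ccccc2)cc1` is the next compound; it differs from compound 2 by chloro in place of hydrogen on an aromatic carbon.

Among the measured compounds shown here, only one measured step bears on the question, and it concerns a different substituent at the same kind of position; that step, a 1.0-fold lower number from compound 1 to compound 2 (0.01 log units; within the scatter), stayed within the scatter. For the measured compounds named here, no measured pair shows a chloro entering anywhere. On that basis no step beyond the scatter is expected for compound 3, and the estimated shift is a 1.0-fold lower number from compound 2 to compound 3 (0.01 log units; within the scatter). The expected value for compound 3 in this assay is 80 nM, within a range from 35 nM to 190 nM.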

Compound 3, half-maximal inhibitory concentration: 76 nM
Compound 3: middle estimate off by 1.1-fold (0.02 log units), on the high side; measured number inside the range.
By their numbers in this assay, from the lowest: compounds 3, 2 and 1 (each within the scatter of the next).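

In this assay, phenyl to 4-chlorophenyl puts a chloro on an aromatic carbon, para to a large group, and this step stays within the scatter (a 1.1-fold lower number from compound 2 to compound 3 (0.03 log units; within the scatter)). The direct comparison of 4-chlorophenyl with 2-methoxyphenyl on the carbon with a double bond to nitrogen also stays within the scatter (a 1.1-fold lower number from compound 1 to compound 3 (0.04 log units; within the scatter)), so phenyl, 2-methoxyphenyl and 4-chlorophenyl cannot be told apart in this assay at this position. Nothing measured here accounts for this flat reading.

On these data alone, whether an amine or a carboxylic acid in place of the chloro would give a step beyond the scatter remains open. As far as these compounds go, the effect of a chloro elsewhere on this ring, and of changes to the shared core, also remains open.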